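A few compounds are considered here, and "the series" means these few. Any claim that something is new, unique, unknown or untested is made for them only; others in the source may bear on it.

Compound 1 `Cn1c(=O)c(S(=O)(=O)Cc2ccc(F)cc2F)cc2cnc(Nc3ccc4[nH]ccc4c3)nc21` stands lowest of the three numbers in a functional assay on K562 cells (Homo sapiens) for inhibition, read by trypan blue exclusion, with a stated time of 72 h (on this read-out higher numbers stand for weaker inhibition and lower numbers for stronger inhibition), where compound 1 gives 1000 nM. Its nearest neighbour, compound 2 `COC(=O)Cn1ccc2cc(Nc3ncc4cc(S(=O)(=O)c5ccc(F)cc5F)c(=O)n(C)c4n3)ccc21`, gives 5000 nM in this assay, a gap beyond the scatter; compound 3 `Cc1ccc(S(=O)(=O)c2cc3cnc(Nc4ccc5ncccc5c4)nc3n(C)c2=O)cc1` gives 10000 nM in this assay and lies furthest from compound 1. Compound 4 `Cn1c(=O)c(S(=O)(=O)c2ccc(Br)cc2)cc2cnc(Nc3ccc4[nH]ccc4c3)nc21` has not yet been measured. It differs from compound 1 in one place: 4-bromophenyl in place of 2,4-difluorobenzyl on a sulfonyl sulfur. Within the data shown here, no step between two measured compounds that differ in a single place is available, and compound 2 and compound 3 each differ from compound 1 in more than one place. With nothing closer to lean on, compound 4 is expected to shift only modestly, a step of a 2.0-fold higher number from compound 1 to compound 4 (0.30 log units; within the scatter) in this assay. The estimate for compound 4 in this assay is 2000 nM, with a range from 700 nM to 6000 nM.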

Compound 4, half-maximal inhibitory concentration: 5000 nM
Estimate against measurement, compound 4: 2.5-fold (0.40 log units) below; low and high end bracket the measured number.
By their numbers in this assay, from the lowest: compound 1; then compounds 2, 4 and 3 (each within the scatter of the next).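

On the sulfonyl sulfur, 4-bromophenyl in place of 2,4-difluorobenzyl gives a 5.0-fold higher number from compound 1 to compound 4 (0.70 log units; beyond the scatter) in this assay. Among these compounds, this is the first comparison with the rest of the structure held constant, and it shows that inhibition on this read-out is sensitive to the group at this position. No measurement shown here accounts for the step.

The change replaces the benzyl group with a phenyl group and swaps the halogens in a single step, so the compounds shown cannot separate these two contributions. As far as these compounds go, how a 4-bromobenzyl group or a 2,4-difluorophenyl group would behave at this position remains open.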